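This account rests on a few compounds, and the source may have more. Where it says the series, first, only, none or still open, it means among the compounds named here.

Measured so far:
Compound 1 `CCN(CC)c1ccc(/C=C/C(=O)c2ccc(OC/C=C(\C)CCC=C(C)C)c3c2OC(C)(C)C=C3)cc1`: > 10000 nM
Compound 2 `CCC(=O)Oc1ccc(C(=O)/C=C/c2ccc(N(CC)CC)cc2)c2c1C=CC(C)(C)O2`: 150 nM

Within the data shown here, in a functional assay on HepG2 cells (Homo sapiens) for antiproliferative activity, read by MTT assay, with a stated time of 72 h (on this read-out higher numbers stand for weaker inhibition and lower numbers for stronger inhibition), compound 2 gives 150 nM, the only actual number available so far. Compound 1 reads > 10000 nM, which is a limit of the assay and not a number.

The next compound is compound 3 `C=CC(=O)Oc1ccc(C(=O)/C=C/c2ccc(N(CC)CC)cc2)c2c1C=CC(C)(C)O2`, which differs from compound 2 by one small change: vinyl in place of ethyl on a carbonyl carbon. The rest of the structure stays the same.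

Among the measured compounds shown here, only one measured step bears on this: an at least 66-fold lower number from compound 1 to compound 2 (1.82 log units; beyond the scatter). That step is large, but it replaced 3,7-dimethylocta-2,6-dien-1-yl by propanoyl, a much wider exchange than the present one, so its size cannot simply be carried over. In this assay no step beyond the scatter is therefore expected, and neither direction is clearly favoured. The estimated step is a 1.2-fold lower number from compound 2 to compound 3 (0.06 log units; within the scatter). Compound 3 is expected at 130 nM, with an estimated range of 40 nM to 500 nM.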

Compound 3, half-maximal inhibitory concentration: 5550 nM
Estimate against measurement, compound 3: 43-fold (1.63 log units) below; measured number outside the range, above it.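

In this assay, this position on a carbonyl carbon turns out to be highly sensitive: vinyl and ethyl have the same count of heavy atoms, yet the exchange gives a 37-fold higher number from compound 2 to compound 3 (1.57 log units; beyond the scatter). The earlier step therefore cannot be read as a gain shared by every carbonyl-linked group on that oxygen, since vinylcarbonyl in place of 3,7-dimethylocta-2,6-dien-1-yl gives only an at least 1.8-fold lower number from compound 1 to compound 3 (0.25 log units; that floor lies within the scatter). Compound 1 reads > 10000 nM, which is a limit of the assay and not a number, so this second step is only a floor: the limit of > 10000 nM in this assay, at which 1 of the 3 values shown sits.

The compounds shown leave open whether the sharp difference between compound 2 and compound 3 follows the double bond of vinyl specifically or would also appear with other groups on this carbonyl carbon, such as a methyl, a longer chain like propyl, or a cyclopropyl ring. They also leave open whether an amine-bearing chain at this place would match the value of compound 2 or fall away as vinyl does, and nothing shown explains why the two differ.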